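The compounds below may be only part of what the source reports. "The series", "measured", "known", "first", "only" and "open" are said of these compounds alone.

Compound 1, `O=c1nc(N2CCN(NCC3CCCC3)CC2)sc2c([N+](=O)[O-])cc(C(F)(F)F)cc12`: in an ADME assay on Vero cells (Chlorocebus sabaeus) for cytotoxicity, read by MTT assay, with a stated time of 72 h (a higher number here means that more compound is tolerated, a lower number that less compound is tolerated), compound 1 gives > 64 ug/mL, which is a limit of the assay rather than a number.
Compound 2, `CC(C)CN(CC(C)C)N1CCN(c2nc(=O)c3cc(C(F)(F)F)cc([N+](=O)[O-])c3s2)CC1`: compound 2 gives > 64 ug/mL, again a limit of the assay.
Compound 3, `O=c1nc(N2CCN(NCc3ccc(OC(F)(F)F)cc3)CC2)sc2c([N+](=O)[O-])cc(C(F)(F)F)cc12`: compound 3 gives > 64 ug/mL, also a limit of the assay.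

All three measured compounds share the same core and differ only in the group attached to the amine nitrogen in the ring. Compound 2 stands where every measured compound stands, at the limit of > 64 ug/mL in this assay, at which 3 of the 3 values shown sit. The two steps already measured, a step that the two limits leave unreadable from compound 1 to compound 2 and a step that the two limits leave unreadable from compound 1 to compound 3, cannot be read in size, since both of their end points sit at the limit of > 64 ug/mL in this assay, at which 3 of the 3 values shown sit.

Compound 4, `CC(C)(C)c1ccc(CNN2CCN(c3nc(=O)c4cc(C(F)(F)F)cc([N+](=O)[O-])c4s3)CC2)cc1`, has not yet been measured. It differs from compound 2 by (4-(tert-butyl)benzyl)amino in place of diisobutylamino on an amine nitrogen in a ring. Both steps that bear on this change are unreadable, so no direction beyond the scatter can be expected from them in this assay. Compound 4 is therefore expected to give 80 ug/mL, within a range from 40 ug/mL to 200 ug/mL. This estimate means an expected step that the limit leaves unreadable from compound 2 to compound 4, most likely reported again only as a limit.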

Compound 4, half-maximal cytotoxic concentration: > 64 ug/mL
Compound 4: a limit, no number (the forecaster's own chance of this, stated with the estimate: 70%); the middle value does not contradict the limit.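

The steps from compound 1, compound 2 and compound 3 to compound 4 cannot be read in this assay, since all four compounds give a limit rather than a number: the limit of > 64 ug/mL in this assay, at which 4 of the 4 values shown sit.

The compounds shown leave open what each compound's actual value is and whether these groups differ at all in this assay.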